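The source may hold more compounds than are shown below. What is called first, only, known or untested is meant among the compounds shown, and "the series" means these compounds.

Working notes on the enone series. Compound 1 `COc1cc(-c2cc(/C=C/C(=O)c3ccc(C)cc3)nc3cc(-c4ccccc4)nn23)cc(OC)c1OC` gives 27100 nM in a functional assay on DU-145 cells (Homo sapiens) for antiproliferative activity, read by MTT assay, with a stated time of 24 h; a lower number here means a stronger inhibitor, a higher number a weaker inhibitor. Compound 2 `COc1ccc(C(=O)/C=C/c2cc(-c3ccc(OC)c(OC)c3)n3nc(-c4ccccc4)cc3n2)cc1` gives 14600 nM in this assay. Compound 3 `COc1ccc(/C=C/C(=O)c2cc(-c3cc(OC)c(OC)c(OC)c3)n3nc(-c4ccccc4)cc3n2)cc1OC` gives 15300 nM in this assay, the second highest of the three numbers; its nearest neighbour is compound 2, within the scatter, and its furthest is compound 1, also within the scatter. On the numbers shown, the three measured compounds cannot be separated.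

Compound 4 `COc1cc(/C=C/C(=O)c2cc(-c3cc(OC)c(OC)c(OC)c3)n3nc(-c4ccccc4)cc3n2)cc(OC)c1OC` is the next member. It differs from compound 3 by methoxy in place of hydrogen on an aromatic carbon, so the aryl on the enone side goes from 3,4-dimethoxyphenyl to 3,4,5-trimethoxyphenyl. Going by the values given here, no step between measured compounds gives a precedent for this change, and the spread among compounds 1 to 3 is all within the scatter. The expected step in this assay from compound 3 to compound 4 is therefore a 1.3-fold lower number from compound 3 to compound 4 (0.11 log units; within the scatter), none beyond the scatter, with a slight lean to a lower number. Compound 4 is estimated at 12000 nM, with a range of 5000 nM to 30000 nM.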

Compound 4, half-maximal inhibitory concentration: 17900 nM
Compound 4: middle estimate off by 1.5-fold (0.17 log units), on the low side; low and high end bracket the measured number.
By their numbers in this assay, from the lowest: compounds 2, 3, 4 and 1 (each within the scatter of the next).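

Going by these compounds alone, the step from 3,4-dimethoxyphenyl to 3,4,5-trimethoxyphenyl on the enone side is the first single-place comparison, and it gives a 1.2-fold higher number from compound 3 to compound 4 (0.07 log units; within the scatter) in this assay. At this aromatic carbon, ortho to a methoxy group, the extra methoxy therefore leaves two values that cannot be separated, so this aryl carries a third methoxy without a measurable difference in this read-out. No supporting measurement is available to explain this result.

As far as these compounds go, whether a different group at this carbon, such as an amine or a carboxylic acid, would produce a step beyond the scatter remains open. It is also open whether the methoxy groups already on this aryl contribute at all, since the compounds shown include no unsubstituted phenyl at this place.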